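Dropping the Nitro Group from a Urea Cytotoxicity Lead

The source may hold more compounds than are shown below. What is called first, only, known or untested is meant among the compounds shown, and "the series" means these compounds.

Within the data shown here, compound 2 `O=C(Nc1ccccc1[N+](=O)[O-])N[C@H]1CC[C@H](Oc2ccc(F)cc2)CC1` is the only compound in this set with a numeric result: in a functional assay on CRL2813 cells (Homo sapiens) for cytotoxicity, read by sulforhodamine B assay, with a stated time of 5 days (a higher number here means a weaker inhibitor, a lower number a stronger inhibitor), compound 2 gives 3500 nM. Compound 1 `O=C(Nc1cccc(C(F)(F)F)c1)N[C@H]1CC[C@H](O)CC1` gives only a limit of the assay in this assay, namely > 20000 nM. Among the measured compounds shown here, because compound 1 sits at the limit of > 20000 nM in this assay, at which 1 of the 2 values shown sits, no step between the two measured compounds can be sized, and the two differ in more than one place anyway. Compound 3 `O=C(Nc1ccccc1)N[C@H]1CC[C@H](Oc2ccc(F)cc2)CC1` differs from compound 2 in a single respect: hydrogen in place of nitro on an aromatic carbon. For the measured compounds named here, with no measured step of this kind to lean on, the size of the change is open; the expectation is a step of a 1.7-fold higher number from compound 2 to compound 3 (0.23 log units; within the scatter) in this assay, a loss of potency that may not clear the usual scatter. Compound 3 is therefore estimated at 6000 nM in this assay, with a range from 2000 nM to 20000 nM.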

Compound 3, half-maximal inhibitory concentration: 20000 nM
Beside the measured number, compound 3's estimate is 3.3-fold (0.52 log units) below it, and the stated range covers the measured number.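

Among these compounds, the 2-nitrophenyl to phenyl change gives the first step in this set that can be sized, a 5.7-fold higher number from compound 2 to compound 3 (0.76 log units; beyond the scatter) in this assay, so the nitro group on this aromatic carbon, ortho to a large group, contributes measurably to the activity of compound 2. The 4-fluorophenoxy-bearing core alone, with an unsubstituted phenyl on the urea, therefore does not hold that activity in full. Among the compounds shown here, compound 1 stays a limit of the assay and not a number, and no step to it can be read: the limit of > 20000 nM in this assay, at which 1 of the 3 values shown sits.

As far as these compounds go, whether the nitro group itself is needed, or whether an amine or a nitrile at the same place would serve as well, stays open. Also open, from the compounds shown here alone, is how a nitro group at another carbon of this ring would compare.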